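This account rests on a few compounds, and the source may have more. Where it says the series, first, only, none or still open, it means among the compounds named here.

Measured in a functional assay on KB cells (Homo sapiens) for inhibition; on this read-out higher numbers stand for weaker inhibition and lower numbers for stronger inhibition:
Compound 1 `CNc1nc2cc(Cl)c(Cl)cc2n1COC(CO)CO` gives > 100000 nM, a limit of the assay.
Compound 2 `CN(C)c1nc2c(Cl)cc(Cl)cc2n1COC(CO)CO` gives > 100000 nM, a limit of the assay.
Compound 3 `CNc1nc2c(Cl)c(Cl)ccc2n1COC(CO)CO` gives > 100000 nM, a limit of the assay.

Among the measured compounds shown here, compound 1 stands at the limit of this assay, where the other two measured compounds also sit, so no step between measured compounds can be sized; all three share (the limit of > 100000 nM in this assay, at which 3 of the 3 values shown sit). Compound 4 `OCC(CO)OCn1c(S)nc2cc(Cl)c(Cl)cc21` is not yet measured. It differs from compound 1 in one place: sulfanyl in place of methylamino on an aromatic carbon. Since compound 1 sits at the limit of > 100000 nM in this assay, at which 3 of the 3 values shown sit, together with every measured neighbour, no change beyond the scatter is expected in this assay. The expected step is a number no higher from compound 1 to compound 4 (the limit leaves the size open), none beyond the scatter. For compound 4 the estimate is 100000 nM, in the range 30000 nM to 300000 nM, most likely reported again as a limit rather than a number.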

Compound 4, half-maximal inhibitory concentration: > 100000 nM
Compound 4: only a limit was reported; the forecaster's own chance of this, stated with the estimate: 85%; the middle value sits exactly at the limit.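

No step can be read between compound 1 and compound 4, since each stands only as a limit in this assay: the limit of > 100000 nM in this assay, at which 4 of the 4 values shown sit.
The compounds shown leave open which change to the shared core, if any, would give a readable value in this assay.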